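The source may report more compounds than this note shows. Statements on the series, on what has been measured and on what is new or still open speak of the compounds shown alone.

Measured so far in an ADME assay on THP-1 cells (Homo sapiens) for cytotoxicity, read by flow cytometry and propidium iodide staining, with a stated time of 72 h; on this read-out lower numbers stand for stronger inhibition and higher numbers for weaker inhibition:
Compound 1 `COc1ccccc1-c1oc2ccc(NC(C)=O)cc2c(=O)c1O`: > 125000 nM (a limit of the assay, not a number)
Compound 2 `CC(=O)Nc1ccc2oc(-c3cccc(F)c3)c(O)c(=O)c2c1`: 36000 nM
Compound 3 `CC(=O)Nc1ccc2oc(-c3cccc(C(F)(F)F)c3)c(O)c(=O)c2c1`: 1000 nM

Of the two actual numbers in this assay, the higher belongs to compound 2 at 36000 nM and the lower to compound 3 at 1000 nM. Compound 1 is recorded only at a limit, > 125000 nM.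

Compound 4 `Nc1ccc2oc(-c3cccc(F)c3)c(O)c(=O)c2c1` departs from compound 2 at a single place: hydrogen in place of acetyl on a nitrogen on an aromatic ring. In words, hydrogen stands in place of acetyl on a nitrogen on an aromatic ring, so acetamido becomes amino.

Two measured steps lead to or from compound 2: an at least 3.4-fold lower number from compound 1 to compound 2 (0.54 log units; beyond the scatter) and a 36-fold lower number from compound 2 to compound 3 (1.56 log units; beyond the scatter). Both are changes on an aromatic carbon, and compound 1, compound 2 and compound 3 all carry the acetamido unchanged. These steps therefore show that single changes can move this read-out considerably, but they do not measure the present change or fix its direction. A modest move toward a lower number is a tentative expectation, with a wide margin on either side. The expected change is a 2.4-fold lower number from compound 2 to compound 4 (0.38 log units; beyond the scatter). For compound 4 the estimated value is 15000 nM, with an expected range from 4000 nM to 60000 nM.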

Compound 4, half-maximal inhibitory concentration: 30000 nM
Compound 4: the middle estimate sits 2.0-fold (0.30 log units) below what was measured; the measured number falls inside the stated range.
By their numbers in this assay, from the lowest: compound 3; then compounds 4 and 2 (each within the scatter of the next). At a limit, above all of these: compound 1.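

In this assay, hydrogen in place of acetyl on a nitrogen on an aromatic ring gives a 1.2-fold lower number from compound 2 to compound 4 (0.08 log units; within the scatter), the only reading of this place among the compounds shown, since the other compounds all carry the acetamido unchanged. With the 3-fluorophenyl kept in place, the acetyl can therefore be lost without the number leaving the scatter, whereas a single change on an aromatic carbon gave a 36-fold lower number from compound 2 to compound 3 (1.56 log units; beyond the scatter), so this nitrogen is, on this one pair, a far quieter place than that carbon. Nothing measured here explains why the swap leaves the read-out where it stands.

Going by these compounds, it stays open whether acetamido to amino would read the same with the trifluoromethyl of compound 3 in place of fluoro, where the number starts much lower, as this single pair cannot show whether the result carries over to another aryl group. Also open, on these data alone, is how this nitrogen would respond to a longer acyl chain such as propionyl, to a simple methyl group or to a methanesulfonyl group in place of the acetyl.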